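A few compounds are considered here, and "the series" means these few. Any claim that something is new, unique, unknown or untested is made for them only; others in the source may bear on it.

Measured compounds:
compound 1, `Cc1ccc(/C=C/c2nc3cc(Br)ccc3[nH]c2=O)cc1`, 0.0168 ug/mL in a functional assay on SF-268 cells (Homo sapiens) for inhibition, read by sulforhodamine B assay, with a stated time of 72 h; on this read-out lower numbers stand for stronger inhibition and higher numbers for weaker inhibition
compound 2, `Cc1nc2cc(Br)ccc2n(CC(=O)NN)c1=O`, 0.00006 ug/mL in this assay
compound 3, `Cc1nc2cc(Br)ccc2nc1Oc1ccc(N)cc1`, 0.00008 ug/mL in this assay

Of the three numbers, compound 3 has the second highest. Its nearest neighbour is compound 2, and the two values lie within the scatter of each other, so nothing separates them. Compound 1 stands furthest away, with a number that is higher than that of compound 3 by an amount well beyond the scatter, so compound 1 is the weaker inhibitor of that pair in this assay.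

Compound 4, `Cc1nc2cc(Br)ccc2nc1Oc1ccc(/C=N\c2ccc(Cl)cc2)cc1`, has not been measured. It differs from compound 3 in one place: a group of 9 heavy atoms (7 carbon, 1 nitrogen, 1 chlorine; one six-membered aromatic ring of carbon only) in place of one nitrogen atom, on an aromatic carbon. Among the measured compounds shown here, no step between two measured compounds resembles this change, so its effect cannot be read from the data. The account nonetheless expects that compound 4 will give a number above that of compound 3 in this assay, because the value of compound 3, 0.00008 ug/mL, already sits at the low end of what has been seen and the replacement adds many heavy atoms where a single nitrogen stood. The expected step from compound 3 to compound 4 is a 6.3-fold higher number from compound 3 to compound 4 (0.80 log units; beyond the scatter). The estimate for compound 4 is 0.0005 ug/mL, with a range from 0.00005 ug/mL to 0.01 ug/mL.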

Compound 4, half-maximal inhibitory concentration: 0.0304 ug/mL
Compound 4: middle estimate off by 61-fold (1.78 log units), on the low side; the whole stated range lies below it.
By their numbers in this assay, from the lowest: compounds 2 and 3 (each within the scatter of the next); then compounds 1 and 4 (each within the scatter of the next).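

At the aromatic carbon para to a large group, the amino group of compound 3 cannot be swapped freely: in this assay, replacing it with the group of 9 heavy atoms, which brings a six-membered aromatic ring of carbon only and a double bond outside aromatic rings, gives a 380-fold higher number from compound 3 to compound 4 (2.58 log units; beyond the scatter), a large loss of inhibition beyond the scatter. Among the compounds shown here, the earlier compounds offered no step in one place, so this is the first change in the set whose effect can be read directly, and it shows that this position is sensitive to what it carries, at least for this replacement. Nothing available here explains why the number rises so far.

For the compounds shown here, the single step changes several things at once, so it remains open whether the loss follows from the added ring, the chlorine or the double bond outside aromatic rings. Going by these compounds, it also remains open how smaller groups at this position would behave, such as a hydroxyl, a methyl or an acetamide, or how the same group without its chlorine would compare with compound 4.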